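Swapping Fluoro for Chloro on a Low-Lipophilicity Compound

A few compounds are considered here, and "the series" means these few. Any claim that something is new, unique, unknown or untested is made for them only; others in the source may bear on it.

compound 1 `Cc1cc2nc(O)c(O)nc2c([N+](=O)[O-])c1C`: 0.58
compound 2 `CCc1cc2nc(O)c(O)nc2c([N+](=O)[O-])c1Br`: 1.04
compound 3 `Cc1c(F)cc2nc(O)c(O)nc2c1[N+](=O)[O-]`: 0.08

All three were measured in a physicochemical assay for lipophilicity; on this read-out lower numbers stand for lower lipophilicity and higher numbers for higher lipophilicity. Compound 3 stands lowest of the three at 0.08, with compound 1 nearest at 0.58 and compound 2 furthest at 1.04.

The next compound to be read is compound 4 `Cc1c(Cl)cc2nc(O)c(O)nc2c1[N+](=O)[O-]`, which has chloro in place of fluoro on an aromatic carbon. Going by the values given here, this exact exchange has not been measured, and no measured compound carries chloro. Among the compounds with values here, no measured step involves compound 2 either, so its value offers only the upper end of the range seen so far.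

Within the data shown here, one measured step bears on the question, though only indirectly. It is a number 0.50 log units lower from compound 1 to compound 3 (beyond the scatter), a modest move made when fluoro took the place of methyl on an aromatic carbon. Here fluoro leaves instead of entering, so a move in the opposite direction and of similar modest size is expected in this assay. The estimated change is a number 0.47 log units higher from compound 3 to compound 4 (beyond the scatter). For compound 4 the estimated value is 0.55, with an expected range from 0.2 to 0.9.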

Compound 4, partition coefficient: 0.49
For compound 4 the middle estimate is 0.06 log units above the measured one; the range from low to high includes it.
By their numbers in this assay, from the lowest: compound 3; then compounds 4 and 1 (each within the scatter of the next); then compound 2.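

Compound 4 gives this position its first chloro, and in this assay the exchange of fluoro for chloro on this aromatic carbon, ortho to a methyl group, moves the read-out directly: a number 0.41 log units higher from compound 3 to compound 4 (beyond the scatter). The second new step changes the picture of the position more. It compares chloro with methyl, the group that stood there in compound 1, and gives a number 0.09 log units lower from compound 1 to compound 4 (within the scatter). Among the three compounds that differ only at this carbon, fluoro is therefore the one that stands apart, while chloro and methyl cannot be told apart on this read-out, and nothing shown here accounts for that.

What the compounds shown leave open is whether an amine or a methoxy group on this same carbon would fall with fluoro or sit with chloro and methyl. Compound 2 differs from the others in more than one place, so it cannot show whether fluoro would stand apart in the same way on a core carrying ethyl and bromo.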